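The source may report more compounds than this note shows. Statements on the series, on what has been measured and on what is new or still open speak of the compounds shown alone.

Compound 1 `CN1CCN(c2nc(Nc3ccc(C#N)c(C(F)(F)F)c3)nc(Oc3ccnc4ccccc34)n2)CC1`: in a functional assay on DU-145 cells (Homo sapiens) for cytotoxicity, read by sulforhodamine B assay, with a stated time of 48 h (a lower number here means that less compound is tolerated, a higher number that more compound is tolerated), compound 1 gives > 100000 nM, which is a limit of the assay.
Compound 2 `COc1ccc(N2CCN(c3nc(Nc4ccc(C#N)c(C(F)(F)F)c4)nc(Oc4ccnc5ccccc45)n3)CC2)cc1`: in this assay compound 2 gives > 100000 nM, also a limit.
Compound 3 `N#Cc1ccc(Nc2nc(Oc3ccnc4ccccc34)nc(N3CCN(c4ccccc4F)CC3)n2)cc1C(F)(F)F`: in this assay compound 3 gives > 100000 nM, again a limit.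

Compound 1 stands where every measured member of the series stands: all three values sit at the same limit (the limit of > 100000 nM in this assay, at which 3 of the 3 values shown sit). The steps a step that the two limits leave unreadable from compound 1 to compound 2, a step that the two limits leave unreadable from compound 1 to compound 3 and a step that the two limits leave unreadable from compound 2 to compound 3 carry no readable size. Compound 4 `N#Cc1ccc(Nc2nc(Oc3ccnc4ccccc34)nc(N3CCCCC3)n2)cc1C(F)(F)F` differs from compound 1 by piperidin-1-yl in place of 4-methylpiperazin-1-yl on an aromatic carbon. For the measured compounds named here, no measured step touches this change, and no measured step gives a readable size at all. For compound 4 the value in this assay is expected to sit at the limit again, so that a number no higher from compound 1 to compound 4 (the limit leaves the size open) is expected to be no readable step. The estimate for compound 4 is 100000 nM, within 30000 nM to 300000 nM.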

Compound 4, concentration lethal to 50% of the cells: > 100000 nM
Compound 4: a limit, no number; the forecaster's own chance of this, stated with the estimate: 80%; the middle value lies on the limit itself.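

In this assay compound 4 gives > 100000 nM, a limit and not a number. For the compounds shown here, no step can therefore be read between compound 1 and compound 4. The compounds shown leave open where any true value lies and whether any of these substituent changes alters it.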